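The source may report more compounds than this note shows. Statements on the series, on what has been measured and on what is new or still open speak of the compounds shown alone.

Measured so far:
- Compound 1 `OC[C@H]1O[C@@H](n2cnc3c(SCC4CCCCC4)ncnc32)[C@H](O)[C@@H]1O`: in an assay on isolated protein for binding affinity to Equilibrative nucleoside transporter 1 (Homo sapiens) (on this read-out higher numbers stand for weaker inhibition and lower numbers for stronger inhibition), compound 1 gives 1550 nM.
- Compound 2 `Cc1cc(C)c(SCc2ncnc3c2ncn3[C@@H]2O[C@H](CO)[C@@H](O)[C@H]2O)c(C)c1`: in this assay compound 2 gives 33100 nM.
- Compound 3 `OC[C@H]1O[C@@H](n2cnc3c(CSc4ccccc4I)ncnc32)[C@H](O)[C@@H]1O`: in this assay compound 3 gives 282 nM.

Compound 3 holds the lowest number of the three; both steps toward it, a 5.5-fold lower number from compound 1 to compound 3 (0.74 log units; beyond the scatter) and a 120-fold lower number from compound 2 to compound 3 (2.07 log units; beyond the scatter), lie beyond the scatter.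

Compound 4 `OC[C@H]1O[C@@H](n2cnc3c(CSc4cccc(I)c4)ncnc32)[C@H](O)[C@@H]1O` differs from compound 3 by 3-iodophenyl in place of 2-iodophenyl on a sulfur. Among the measured steps only a 120-fold lower number from compound 2 to compound 3 (2.07 log units; beyond the scatter) touches the aryl group on the sulfur, and there the whole aryl group was exchanged, so it shows that this part of the molecule matters a great deal but says nothing about moving the iodine within the ring. a 5.5-fold lower number from compound 1 to compound 3 (0.74 log units; beyond the scatter) concerns a different part of the molecule and gives no guide here. Within the data shown here, no measured pair anchors the direction of the present step. A step of modest size in this assay is therefore expected, with direction open, and the estimate for compound 4 is 500 nM, range 150 nM to 2000 nM, meaning a 1.8-fold higher number from compound 3 to compound 4 (0.25 log units; within the scatter) is expected.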

Compound 4, half-maximal inhibitory concentration: 245 nM
Compound 4: middle estimate off by 2.0-fold (0.31 log units), on the high side; the measured number falls inside the stated range.
By their numbers in this assay, from the lowest: compounds 4 and 3 (each within the scatter of the next); then compound 1; then compound 2.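

Exchanging 2-iodophenyl for 3-iodophenyl on the sulfur gives a 1.2-fold lower number from compound 3 to compound 4 (0.06 log units; within the scatter) in this assay, so this shift of the iodine within the aryl ring leaves the read-out effectively unchanged. The large distance from the 2,4,6-trimethylphenyl compound holds for the 3-iodophenyl group as well, at a 140-fold lower number from compound 2 to compound 4 (2.13 log units; beyond the scatter), and the distance from the cyclohexyl-bearing compound also holds, at a 6.3-fold lower number from compound 1 to compound 4 (0.80 log units; beyond the scatter). No supporting evidence bears on why the two iodophenyl groups read alike.

Still open, going by these compounds, is whether the iodine itself contributes, as a plain phenyl group on the sulfur would show. Also open, on these data alone, is how the read-out responds when an amine or a carboxylic acid replaces the iodine on this ring.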